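The compounds below may be only part of what the source reports. "The series", "measured", "known", "first", "only" and "open" are said of these compounds alone.

In an ADME assay on L02 cells (Homo sapiens) for cytotoxicity, read by MTT assay, with a stated time of 24 h (a higher number here means a weaker inhibitor, a lower number a stronger inhibitor), compound 1 (`O=C1/C(=C/c2cccnc2)CNC/C1=C\c1ccccc1F`) gives 15900 nM and compound 2 (`O=C1/C(=C/c2ccncc2)CNC/C1=C\c1ccccc1F`) gives 14700 nM, so compound 2 stands level with compound 1 within the scatter. Compound 3 (`O=C1/C(=C/c2ccncc2)CN(S(=O)(=O)c2ccc(Cl)cc2)C/C1=C\c1ccccc1F`) follows from compound 2 by (4-chlorophenyl)sulfonyl in place of hydrogen on an amine nitrogen in a ring, with (4-chlorophenyl)sulfonyl in place of hydrogen on an amine nitrogen in a ring. For the measured compounds named here, the only measured step, a 1.1-fold lower number from compound 1 to compound 2 (0.03 log units; within the scatter), lies within the scatter and concerns pyridin-4-yl in place of pyridin-3-yl, so it gives no measure for a change at this nitrogen. With no measured guide, only a modest step is tentatively expected, a 1.6-fold lower number from compound 2 to compound 3 (0.21 log units; within the scatter). The estimated value for compound 3 is 9000 nM, with an expected range from 2500 nM to 35000 nM.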

Compound 3, half-maximal inhibitory concentration: 15000 nM
Estimate against measurement, compound 3: 1.7-fold (0.22 log units) below, and the stated range covers the measured number.
By their numbers in this assay, from the lowest: compounds 2, 3 and 1 (each within the scatter of the next).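

In this assay, the step at the amine nitrogen in the ring is a 1.0-fold higher number from compound 2 to compound 3 (0.01 log units; within the scatter), so this position, untouched by the earlier pair, stays level within the scatter when hydrogen gives way to (4-chlorophenyl)sulfonyl, a group bearing its own aromatic ring. No evidence is available to explain this outcome. Going by these compounds, it remains open whether a methyl or an acetyl group on this nitrogen would also leave the number level. On these data alone, it is equally open whether the (4-chlorophenyl)sulfonyl group would do so with pyridin-3-yl in place of pyridin-4-yl.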